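A few compounds are considered here, and "the series" means these few. Any claim that something is new, unique, unknown or untested is made for them only; others in the source may bear on it.

The measured compounds:
compound 1 `c1ccc(-c2ccc3c(NCCCNCc4ccco4)ccnc3c2)cc1`, 237 10^-6 cm/s
compound 2 `CCC(CC)c1ccc2c(NCCCNCc3cccc(OC)c3O)ccnc2c1`, 23 10^-6 cm/s
compound 3 `COc1cccc(CNCCCNc2ccnc3cc(-c4cccc5ccccc45)ccc23)c1O`, 237 10^-6 cm/s

In an ADME assay for permeability, using PAMPA, with a stated time of 30 min, at pH 7.4 (on this read-out lower numbers stand for lower permeability and higher numbers for higher permeability), compound 1 gives 237 10^-6 cm/s, level with compound 3 at the digits shown, and the two share the highest number of the three. Compound 2 gives the lowest number, far beneath both. Going by the values given here, the single step among the measured compounds, a 10-fold higher number from compound 2 to compound 3 (1.01 log units; beyond the scatter), is large and runs through the same position of the shared core that changes here, but it swaps quite different groups.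

Compound 4 `N#Cc1ccc(Cc2ccc3c(NCCCNCc4ccco4)ccnc3c2)cc1` differs from compound 1 by 4-cyanobenzyl in place of phenyl on an aromatic carbon. Among the compounds with values here, no measured step bears directly on this change; the group that enters is larger than the one that leaves and adds a hydrogen-bond acceptor, but the data hold nothing on what such a swap does in this assay. Compound 4 is therefore expected to stay close to compound 1, with at most a modest drop, so a 1.6-fold lower number from compound 1 to compound 4 (0.20 log units; within the scatter) is expected. The estimate for compound 4 is 150 10^-6 cm/s, within 60 10^-6 cm/s to 320 10^-6 cm/s.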

Compound 4, apparent permeability: 23 10^-6 cm/s
Beside the measured number, compound 4's estimate is 6.5-fold (0.81 log units) above it, and the stated range ends above it.
By their numbers in this assay, from the lowest: compounds 2 and 4 (each within the scatter of the next); then compounds 1 and 3 (each within the scatter of the next).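

In this assay, the change at this position gives a 10-fold lower number from compound 1 to compound 4 (1.01 log units; beyond the scatter) and so brings a second large step at this place on the core. The earlier step had swapped pentan-3-yl for naphthalen-1-yl, a change that brought in aromatic rings where there had been none. Here, both the group that leaves and the group that enters hold one six-membered aromatic ring of carbon only, so the presence of such a ring does not by itself keep the number at the level of compound 1. Nothing at hand accounts for the size of this step.

The compounds shown leave open whether the step follows the nitrile or the carbon link to the ring, which a plain benzyl group and a 4-cyanophenyl group would separate. They also leave open whether 4-cyanobenzyl would give a step of similar size on the side chain of compound 3.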